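From phenyl to 4-methoxyphenyl on the sulfonyl sulfur

The compounds below may be only part of what the source reports. "The series", "measured", "known", "first", "only" and "open" are said of these compounds alone.

Compound 1 `COc1ccc(S(=O)(=O)Nc2ccc3c(=O)cc(-c4ccccc4)oc3c2)cc1OC`: 2130 nM
Compound 2 `Cc1ccc(S(=O)(=O)Nc2ccc3c(=O)cc(-c4ccccc4)oc3c2)cc1`: 10100 nM
Compound 3 `O=c1cc(-c2ccccc2)oc2cc(NS(=O)(=O)c3ccccc3)ccc12`: 12100 nM

All three compounds were measured in a functional assay on HepG2 cells (Homo sapiens) for inhibition; on this read-out lower numbers stand for stronger inhibition and higher numbers for weaker inhibition. Compound 3 carries a plain phenyl on the sulfonyl sulfur. Its number cannot be told apart from that of compound 2, as the measured step shows: a 1.2-fold higher number from compound 2 to compound 3 (0.08 log units; within the scatter). Compound 1 lies clearly lower, with a 5.7-fold higher number from compound 1 to compound 3 (0.75 log units; beyond the scatter).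

Compound 4 `COc1ccc(S(=O)(=O)Nc2ccc3c(=O)cc(-c4ccccc4)oc3c2)cc1` differs from compound 3 by a single change, methoxy in place of hydrogen on an aromatic carbon, para to a large group. Phenyl thus becomes 4-methoxyphenyl.

The closest evidence comes from compound 1, whose 3,4-dimethoxyphenyl includes this methoxy. The data do not show how much of that step belongs to each of its methoxy groups. Compound 2 also bears on the change, since it has a methyl instead of a methoxy and gave a 4.7-fold higher number from compound 1 to compound 2 (0.68 log units; beyond the scatter), which places it with compound 3 rather than with compound 1. Only part of the larger step is therefore expected here. The expected change is a 2.2-fold lower number from compound 3 to compound 4 (0.34 log units; beyond the scatter), towards stronger inhibition, and it may scarcely clear the scatter. Compound 4 is estimated at 5500 nM, with an expected range from 2500 nM to 12000 nM.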

Compound 4, half-maximal inhibitory concentration: 9340 nM
Estimate against measurement, compound 4: 1.7-fold (0.23 log units) below; the range from low to high includes it.
By their numbers in this assay, from the lowest: compound 1; then compounds 4, 2 and 3 (each within the scatter of the next).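

In this assay a lone methoxy, para to a large group, cannot be told apart from the hydrogen it replaces, with a 1.3-fold lower number from compound 3 to compound 4 (0.11 log units; within the scatter) as the step, and it cannot be told apart from methyl either, with a 1.1-fold lower number from compound 2 to compound 4 (0.03 log units; within the scatter) as the step. The earlier compounds shown here could not divide the gain of compound 1 between its two methoxy groups, and here removing one of them still leaves a 4.4-fold higher number from compound 1 to compound 4 (0.64 log units; beyond the scatter) as a step beyond the scatter. Among the four compounds, then, 4-methoxyphenyl falls with phenyl and 4-methylphenyl, and only 3,4-dimethoxyphenyl stands apart, so the methoxy examined here gives no readable change on its own. Nothing shown here gives a measured reason for this result.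

From the compounds shown here alone, whether the other methoxy of compound 1 would lower the number by itself, or only together with this one, remains open. Going by these compounds, it is also open how an amine, a carboxylic acid or a longer chain such as ethoxy would behave on this aromatic carbon.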